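Removing one chloro from the anilino ring of compound 1

The source may hold more compounds than are shown below. What is called first, only, known or untested is meant among the compounds shown, and "the series" means these compounds.

Among the compounds with values here, compound 1 `COc1cccc(/C=C/C(=O)c2sc(Nc3ccc(Cl)c(Cl)c3)nc2C)c1` is the only member of this set that yields a number in a functional assay on PC-3 cells (Homo sapiens) for cytotoxicity, read by MTT assay; a lower number here means a stronger inhibitor, a higher number a weaker inhibitor: compound 1 gives 10100 nM. Compound 2 `COc1ccc(/C=C/C(=O)c2sc(Nc3ccc(Cl)c(Cl)c3)nc2C)cc1` reaches only a limit of the assay, > 25000 nM. Compound 3 `Cc1nc(Nc2ccc(Cl)c(Cl)c2)sc1C(=O)/C=C/c1ccc(Cl)cc1` likewise gives only a limit, > 25000 nM. Compound 1 therefore stands alone as a measurable point, with the other two resting at the limit of > 25000 nM in this assay, at which 2 of the 3 values shown sit.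

Compound 4 `COc1cccc(/C=C/C(=O)c2sc(Nc3ccc(Cl)cc3)nc2C)c1` differs from compound 1 by hydrogen in place of chloro on an aromatic carbon.

Within the data shown here, none of the measured steps covers this side of the molecule. The steps of an at least 2.4-fold higher number from compound 1 to compound 2 (0.39 log units; beyond the scatter) and an at least 2.4-fold higher number from compound 1 to compound 3 (0.39 log units; beyond the scatter) both exchange the aryl on the double-bonded chain carbon and both weaken the compound by at least a modest amount, while a step that the two limits leave unreadable from compound 2 to compound 3 cannot be read from two limits. Among the measured compounds shown here, the (3,4-dichlorophenyl)amino portion is the same in all three measured compounds, so the effect of trading it for (4-chlorophenyl)amino has no direct precedent here.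

The expected step is a 1.4-fold higher number from compound 1 to compound 4 (0.14 log units; within the scatter), small in either direction, with a real chance that compound 4 also falls to a limit in this assay. For compound 4 the estimated value is 14000 nM, with a range from 6000 nM to 35000 nM.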

Compound 4, half-maximal inhibitory concentration: > 25000 nM
Compound 4 was reported as a limit (the forecaster's own chance of this, stated with the estimate: 30%); at least 1.7-fold (0.25 log units) between middle value and limit.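

Within the data shown here, this is the first change on the anilino side of the series, and in this assay hydrogen in place of chloro gives an at least 2.4-fold higher number from compound 1 to compound 4 (0.39 log units; beyond the scatter), so the second chloro of the (3,4-dichlorophenyl)amino group cannot be dropped without losing the measurable value of compound 1. Compound 4 gives only a limit, > 25000 nM. Compound 1 remains the only measurable point, since each single change from it shown here, whether on the aryl of the chain or now on the anilino ring, ends at a limit: the limit of > 25000 nM in this assay, at which 3 of the 4 values shown sit.

Still open, on these data alone, is whether another group at this place, ortho to the remaining chloro group, such as fluoro, methyl or trifluoromethyl, would hold or improve on the value of compound 1, which would show whether chloro itself matters or only an occupied position. Equally open, as far as these compounds go, is what a plain phenylamino group, with the remaining chloro also gone, would give, and whether an amine or a carboxylic acid on this ring would bring the series clear of the limit.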